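Trading a 4-methylphenyl amide for a 4-fluorobenzyl amide

The source may hold more compounds than are shown below. What is called first, only, known or untested is meant among the compounds shown, and "the series" means these compounds.

Of the compounds shown here, two sharing one core have been measured so far. Compound 1 `COc1ccc2c(=O)c(/C=C/C(=O)Nc3ccc(C)cc3)coc2c1` gives 979000 nM in an ADME assay on HepG2 2.2.15 cells (Homo sapiens) for cytotoxicity, read by MTT assay, with stated times of 48 h and 9 days (a lower number here means that less compound is tolerated, a higher number that more compound is tolerated), the higher of the two numbers recorded. Compound 2 `Cc1ccccc1NC(=O)/C=C/c1coc2cc(O)ccc2c1=O` gives 374000 nM in this assay, a lower number that lies beyond the usual scatter, so compound 1 is the better tolerated of the pair on these two readings alone.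

Compound 3 `COc1ccc2c(=O)c(/C=C/C(=O)NCc3ccc(F)cc3)coc2c1` has not yet been measured. It differs from compound 1 in a single place: 4-fluorobenzyl in place of 4-methylphenyl on an amide-type nitrogen. Nothing else on the shared core changes.

Within the data shown here, no pair of measured compounds shows this particular change, so its effect can only be estimated from the values at hand. Both measured numbers sit in a narrow band near the top of the scale, and the change from compound 1 to compound 3 touches only the group on the amide nitrogen. The step of a 1.4-fold lower number from compound 1 to compound 3 (0.15 log units; within the scatter) is therefore expected to be small, most likely a modest drop, and is not expected to exceed the scatter of this assay with confidence. Compound 3 is accordingly expected to give about 700000 nM in this assay, within a range of 300000 nM to 1500000 nM.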

Compound 3, half-maximal cytotoxic concentration: 133000 nM
Estimate against measurement, compound 3: 5.3-fold (0.72 log units) above; the whole stated range lies above it.
By their numbers in this assay, from the lowest: compound 3; then compound 2; then compound 1.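

In this assay, among these compounds, the swap of 4-methylphenyl for 4-fluorobenzyl gives a 7.4-fold lower number from compound 1 to compound 3 (0.87 log units; beyond the scatter) and is the first step measured at this position, so less compound is tolerated after this change alone. The group on the amide-type nitrogen therefore matters to this reading, even though everything else on the shared core stays the same and both groups carry one six-membered aromatic ring of carbon only, no hydrogen-bond donors or acceptors, and no net charge. Nothing shown here gives a measured reason for the drop.

The compounds shown leave open which part of the swap carries the step: neither a plain benzyl group nor a 4-fluorophenyl group on this nitrogen stands among them, and these two would separate the fluorine from the change of 4-methylphenyl to a benzyl-type group. Also open, on these data alone, is whether a longer chain ending in the same fluorinated ring would lower the number further, and whether the same swap would have a comparable effect on the core of compound 2.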